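Side-chain ether variation: working notes towards compound 4

The compounds below may be only part of what the source reports. "The series", "measured", "known", "first", "only" and "open" are said of these compounds alone.

Measured in an assay for inhibition of kynurenine 3-monooxygenase (Homo sapiens), read by mass spectrometry, with a stated time of 1 h; a higher number here means a weaker inhibitor, a lower number a stronger inhibitor:
compound 1, `COCCOc1cc2oc(=O)n(CCC(=O)O)c2cc1Cl`: 31.6 nM
compound 2, `O=C(O)CCn1c(=O)oc2cc(OCC3CCC3)c(Cl)cc21`: 25.1 nM
compound 3, `CC(C)Cc1cc2oc(=O)n(CCC(=O)O)c2cc1Cl`: 12.6 nM

Compound 1 gives the highest of the three numbers in this assay. Its nearest neighbour is compound 2, a step of a 1.3-fold lower number from compound 1 to compound 2 (0.10 log units; within the scatter); the furthest is compound 3, a 2.5-fold lower number from compound 1 to compound 3 (0.40 log units; beyond the scatter). Between the other two the step is a 2.0-fold lower number from compound 2 to compound 3 (0.30 log units; within the scatter).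

Compound 4, `O=C(O)CCn1c(=O)oc2cc(OCc3ccccn3)c(Cl)cc21`, departs from compound 1 by pyridin-2-yl in place of methoxymethyl on a saturated chain carbon bound to an oxygen on an aromatic ring. The step that bears on it most directly is the one at the same place, a 1.3-fold lower number from compound 1 to compound 2 (0.10 log units; within the scatter), where one group on the chain carbon bound to the ring oxygen was exchanged for another without a change beyond the scatter. The exchanges on the aromatic carbon, a 2.5-fold lower number from compound 1 to compound 3 (0.40 log units; beyond the scatter) and a 2.0-fold lower number from compound 2 to compound 3 (0.30 log units; within the scatter), were larger but alter a different part of the molecule. Among the compounds with values here, nothing measured so far carries an aromatic ring at the place in question, so the pyridin-2-yl group enters without a direct precedent. The expectation is therefore no step beyond the scatter in this assay, with the direction left open, the estimated step being a 1.3-fold lower number from compound 1 to compound 4 (0.10 log units; within the scatter). Compound 4 is expected to give 25 nM in this assay, with a range from 8 nM to 80 nM.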

Compound 4, half-maximal inhibitory concentration: 3.16 nM
Estimate against measurement, compound 4: 7.9-fold (0.90 log units) above, outside the stated range (below it).
By their numbers in this assay, from the lowest: compound 4; then compounds 3, 2 and 1 (each within the scatter of the next, the first and the last beyond it).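

At the saturated chain carbon bound to an oxygen on an aromatic ring, this assay proves sensitive to the group exchanged: pyridin-2-yl gives a clear drop (a 10-fold lower number from compound 1 to compound 4 (1.00 log units; beyond the scatter)) and a similar drop against cyclobutyl (a 7.9-fold lower number from compound 2 to compound 4 (0.90 log units; beyond the scatter)), whereas the exchange between the two non-aromatic groups stayed small (a 1.3-fold lower number from compound 1 to compound 2 (0.10 log units; within the scatter)). The (pyridin-2-yl)methoxy group also surpasses the isobutyl group on the aromatic carbon (a 4.0-fold lower number from compound 3 to compound 4 (0.60 log units; beyond the scatter)), so compound 4 now has the lowest number of the four, with its steps to all the others beyond the scatter. Nothing at hand explains why this exchange produces these steps.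

The compounds shown do not separate the contribution of the aromatic ring from that of its nitrogen, and a phenyl, pyridin-3-yl or pyridin-4-yl group at this place would address both that question and the importance of where the nitrogen stands. Going by these compounds, it also remains open whether the lower number survives a longer chain between the ring oxygen and the pyridine, as in 2-(pyridin-2-yl)ethoxy, or a methyl group on the pyridine ring.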